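Trifluoromethyl to fluoro on the second arylidene substituent

The source may report more compounds than this note shows. Statements on the series, on what has been measured and on what is new or still open speak of the compounds shown alone.

Measured so far in a functional assay on MCF7 cells (Homo sapiens) for cytotoxicity, read by CCK-8 assay, with a stated time of 72 h; a higher number here means a weaker inhibitor, a lower number a stronger inhibitor:
compound 1 `C=CCn1c(=O)/c(=C\c2ccc(Cl)c(Cl)c2)[nH]c(=O)/c1=C\c1ccccc1OC`: "not active" (no number reported), no number given
compound 2 `C=CCn1c(=O)/c(=C\c2ccccc2OC)[nH]c(=O)/c1=C\c1ccccc1OC`: 41100 nM
compound 3 `C=CCn1c(=O)/c(=C\c2ccccc2C(F)(F)F)[nH]c(=O)/c1=C\c1ccccc1OC`: 6500 nM

Compound 3 holds the lower of the two numbers; the step of a 6.3-fold lower number from compound 2 to compound 3 (0.80 log units; beyond the scatter) lies beyond the scatter, and compound 1 adds no number to compare with.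

Compound 4 `C=CCn1c(=O)/c(=C\c2ccccc2F)[nH]c(=O)/c1=C\c1ccccc1OC` differs from compound 3 by fluoro in place of trifluoromethyl on an aromatic carbon. Among the compounds with values here, the only step at this position, a 6.3-fold lower number from compound 2 to compound 3 (0.80 log units; beyond the scatter), swaps different groups; no measured pair sets trifluoromethyl against fluoro. Compound 4 is therefore expected to land between the numbers of compound 3 and compound 2, nearer the former. The estimate for compound 4 is 15000 nM, range 5000 nM to 45000 nM, which means an expected step of a 2.3-fold higher number from compound 3 to compound 4 (0.36 log units; beyond the scatter).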

Compound 4, half-maximal inhibitory concentration: 23000 nM
The estimate for compound 4 lay 1.5-fold (0.19 log units) below the measured number; measured number inside the range.
By their numbers in this assay, from the lowest: compound 3; then compounds 4 and 2 (each within the scatter of the next).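

In this assay the step of a 3.5-fold higher number from compound 3 to compound 4 (0.55 log units; beyond the scatter) shows that the lower number of compound 3 does not survive the change from trifluoromethyl to fluoro at this position. The step of a 1.8-fold lower number from compound 2 to compound 4 (0.25 log units; within the scatter) lies within the scatter, so fluoro and methoxy cannot be told apart here. Among these three groups, only trifluoromethyl stands apart, on compound 3.

From the compounds shown here alone, whether an amine, a carboxylic acid or a longer chain at this position would match trifluoromethyl stays open. Nothing shown explains the gap between trifluoromethyl and fluoro.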